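Notes on hydroxy to fluoro replacement in the series

The compounds below may be only part of what the source reports. "The series", "measured", "known", "first", "only" and "open" are said of these compounds alone.

- Compound 1 `C/C=C/C(=O)N(Cc1ccc(OC)c([N+](=O)[O-])c1)c1cc(OC)c(OC)c(OC)c1`: 670 nM
- Compound 2 `C/C=C/C(=O)N(Cc1ccc(OC)c(C)c1)c1cc(OC)c(OC)c(OC)c1`: 23500 nM
- Compound 3 `C/C=C/C(=O)N(Cc1ccc(OC)c(O)c1)c1cc(OC)c(OC)c(OC)c1`: 55 nM

In a functional assay on HCT-116 cells (Homo sapiens) for inhibition, read by MTT assay, with a stated time of 48 h (a lower number here means a stronger inhibitor, a higher number a weaker inhibitor), compound 3 gives 55 nM, the lowest of the three numbers. Compound 4 `C/C=C/C(=O)N(Cc1ccc(OC)c(F)c1)c1cc(OC)c(OC)c(OC)c1` differs from it as follows: fluoro in place of hydroxy on an aromatic carbon. This is 3-hydroxy-4-methoxyphenyl to 3-fluoro-4-methoxyphenyl. Two measured steps end on the same hydroxy: a 12-fold lower number from compound 1 to compound 3 (1.09 log units; beyond the scatter) and a 430-fold lower number from compound 2 to compound 3 (2.63 log units; beyond the scatter). Among the measured compounds shown here, both are large and beyond the scatter, though no fluoro compound has been measured. A large rise is therefore expected in this assay, probably of a size nearer the first of these steps. The expected change is a 15-fold higher number from compound 3 to compound 4 (1.16 log units; beyond the scatter). For compound 4 the estimated value is 800 nM, with an expected range of 120 nM to 6000 nM.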

Compound 4, half-maximal inhibitory concentration: 1160 nM
Compound 4: middle estimate off by 1.5-fold (0.16 log units), on the low side, and the stated range covers the measured number.
By their numbers in this assay, from the lowest: compound 3; then compounds 1 and 4 (each within the scatter of the next); then compound 2.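

In this assay, fluoro does not stand in for the hydroxy at this position, with a 21-fold higher number from compound 3 to compound 4 (1.32 log units; beyond the scatter). Fluoro still stands well clear of methyl, with a 20-fold lower number from compound 2 to compound 4 (1.31 log units; beyond the scatter), while a 1.7-fold higher number from compound 1 to compound 4 (0.24 log units; within the scatter) leaves fluoro and nitro not separable, so the order at this position is hydroxy, then fluoro and nitro together, then methyl. Nothing available explains these gaps.

Open, from the compounds shown here alone, is whether the rank of hydroxy is particular to that group, which an amine or a chlorine atom at this position would test. Also open, going by these compounds, is whether these gaps hold outside this one cell assay.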